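From a Thioether to a Benzylamine on a Shared Core

The source may hold more compounds than are shown below. What is called first, only, known or untested is meant among the compounds shown, and "the series" means these compounds.

Compound 1 `Nc1cc(N)c2nc(-c3ccccc3)c(Sc3ccc(F)cc3)nc2c1` was tested in a functional assay on 786-0 cells (Homo sapiens) for inhibition, read by sulforhodamine B assay, with a stated time of 48 h; a higher number here means a weaker inhibitor of growth, a lower number a stronger inhibitor of growth. In this assay compound 1 gives < 100000 nM, which is a limit of the assay and not a number. Compound 3 `CCOC(=O)[C@H](CCC(=O)O)NC(=O)c1ccc(CNc2nc3cc(N)cc(N)c3nc2-c2ccccc2)cc1` also sits at a limit: in this assay compound 3 gives < 100000 nM. Within the data shown here, compound 2 `COc1cc(CNc2nc3cc(N)cc(N)c3nc2-c2ccccc2)cc(OC)c1OC` is the one compound with a measured number, giving in this assay a value of 15500 nM. the limit of < 100000 nM in this assay, at which 2 of the 3 values shown sit, describes where two of the three values stand, so compound 1 cannot be placed in order against compound 2 or compound 3 on these numbers; its standing is an open one.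

Compound 4 `Nc1cc(N)c2nc(-c3ccccc3)c(NCc3ccc(F)cc3)nc2c1` has not yet been measured. It differs from compound 1 in one place: (4-fluorobenzyl)amino in place of (4-fluorophenyl)sulfanyl on an aromatic carbon. Among the measured compounds shown here, no step between measured compounds is recorded, so any expectation for this change rests on compound 2 alone, whose value of 15500 nM in this assay shows that a compound on this core can give a measurable number. Compound 4 is therefore expected to return a number rather than a limit, with an estimated step that the limit leaves unreadable from compound 1 to compound 4. For compound 4 the estimate in this assay is 20000 nM, with a range from 5000 nM to 80000 nM.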

Compound 4, concentration for 50% growth inhibition: 23400 nM
The estimate for compound 4 lay 1.2-fold (0.07 log units) below the measured number, within the range that was stated.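

In this assay compound 1 gives < 100000 nM as a limit of the assay and not a number. Among these compounds, no step from compound 1 to compound 4 can therefore be read, because compound 1 stands at this limit: the limit of < 100000 nM in this assay, at which 2 of the 4 values shown sit. The compounds shown leave open whether (4-fluorobenzyl)amino in place of (4-fluorophenyl)sulfanyl changes growth inhibition at all.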